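The source may report more compounds than this note shows. Statements on the series, on what has been measured and on what is new or still open speak of the compounds shown alone.

In a functional assay on A549 cells (Homo sapiens) for inhibition, read by MTT assay, with a stated time of 48 h (on this read-out lower numbers stand for stronger inhibition and higher numbers for weaker inhibition), two amides built on a shared core have been measured. Compound 1 `COc1ccc(/C=C/c2cc(OC)cc(OC)c2/C=C/C(=O)NC(C)C)cc1` gives 2360 nM, and compound 2 `CCCCCN(CCCCC)C(=O)/C=C/c1c(/C=C/c2ccc(OC)cc2)cc(OC)cc1OC` gives 7490 nM, the higher of the two numbers and so the weaker inhibition. Compound 3 `CCCCCCNC(=O)/C=C/c1c(/C=C/c2ccc(OC)cc2)cc(OC)cc1OC` has yet to be measured. It carries hexylamino in place of dipentylamino on a carbonyl carbon. Going by the values given here, only one measured step bears on this change: a 3.2-fold higher number from compound 1 to compound 2 (0.50 log units; beyond the scatter), a modest step that put dipentylamino in place of isopropylamino. Compound 3 has the amide hydrogen that compound 1 also has and compound 2 lacks, so part of that step may be expected to reverse in this assay. Among the compounds with values here, a hexylamino group is not an isopropylamino group, however, and no measured compound shows what the longer chain does alone, so a full return to the number of compound 1 is not assumed. The expected move is toward a lower number, estimated as a 2.1-fold lower number from compound 2 to compound 3 (0.32 log units; beyond the scatter). For compound 3 the estimated value is 3600 nM, with an expected range of 1500 nM to 8000 nM.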

Compound 3, half-maximal inhibitory concentration: 6230 nM
Estimate against measurement, compound 3: 1.7-fold (0.24 log units) below, and the stated range covers the measured number.
By their numbers in this assay, from the lowest: compound 1; then compounds 3 and 2 (each within the scatter of the next).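

In this assay, hexylamino in place of dipentylamino on a carbonyl carbon gives a 1.2-fold lower number from compound 2 to compound 3 (0.08 log units; within the scatter), so bringing back the amide hydrogen with a long chain leaves compound 3 not separable from compound 2. Compound 1 and compound 3 both carry the amide hydrogen and differ only in the chain on the amide-type nitrogen, and hexyl in place of isopropyl gives a 2.6-fold higher number from compound 1 to compound 3 (0.42 log units; beyond the scatter); the amide hydrogen alone therefore does not bring the number back to that of compound 1, and among these three amides only the isopropylamino compound stands apart from the others. No measurement offered here accounts for this result.

On these data alone, whether the gap between compound 1 and compound 3 follows the length of the chain or its branching stays open, and a straight propyl chain or a butyl chain on the same nitrogen would bear directly on that question. Also open, as far as these compounds go, is how a ring amine such as morpholine, or a chain ending in a carboxylic acid, would read at this position.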